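Propyl Added at Sulfur: What Compound 4 Might Show

The source may hold more compounds than are shown below. What is called first, only, known or untested is meant among the compounds shown, and "the series" means these compounds.

Three compounds with a shared core were tested in a functional assay on SMMC-7721 cells (Homo sapiens) for cytotoxicity, read by MTT assay, with a stated time of 72 h; on this read-out higher numbers stand for weaker inhibition and lower numbers for stronger inhibition. Compound 1 `O=C(CSC(=S)N[C@H]1CCOC1=O)Nc1ccc(Cl)cc1` gives > 128000 nM, which is a limit of the assay rather than a number. Compound 2 `CC(=O)c1ccc(NC(=O)CSC(=S)N[C@H]2CCOC2=O)cc1` likewise gives > 128000 nM, again a limit. Compound 3 `CSC(=S)N[C@H]1CCOC1=O` gives > 128000 nM, also a limit. Within the data shown here, the only single change between measured compounds, a step that the two limits leave unreadable from compound 1 to compound 2, cannot be sized because the limit of > 128000 nM in this assay, at which 3 of the 3 values shown sit, holds both of its ends. Compound 3 therefore stands exactly where every other value stands, and nothing among the shown numbers separates it from compound 1 or compound 2.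

Compound 4 `CCCCSC(=S)N[C@H]1CCOC1=O` differs from compound 3 by propyl in place of hydrogen on a saturated chain carbon bound to a sulfur. Among the measured compounds shown here, no measured step touches this position, and the one recorded step, from compound 1 to compound 2, is unreadable, so there is no basis for expecting either a gain or a loss of potency. For the measured compounds named here, every value so far sits at the limit, and a further limit is therefore the most likely outcome in this assay. Compound 4 is expected to give about 150000 nM, with a range from 60000 nM to 500000 nM. The step that the limit leaves unreadable from compound 3 to compound 4 implied by this estimate is expected to be none beyond the scatter.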

Compound 4, half-maximal inhibitory concentration: > 128000 nM
Compound 4 was reported as a limit; the forecaster's own chance of this, stated with the estimate: 85%; the middle value lies beyond the limit too.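

No size can be read for the change from compound 3 to compound 4 in this assay, because both compounds give a limit rather than a number: the limit of > 128000 nM in this assay, at which 4 of the 4 values shown sit. The compounds shown leave open whether anything built on this shared core acts on these cells strongly enough to give a number, and which changes would matter.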